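The source may report more compounds than this note shows. Statements on the series, on what has been measured and on what is new or still open speak of the compounds shown alone.

Series notes. Compound 2 `Nc1scc(CN2CCN(C3CCCC3)CC2)c1C(=O)c1ccc(Cl)cc1` gives 3% in an assay on CHO cells for displacement of a labelled ligand from adenosine receptor A3 (Homo sapiens), read by scintillation counting, with a stated time of 120 min, tested at 10 uM; a higher number here means more inhibition at the concentration tested (going by the name of the read-out), a lower number less inhibition. Compound 1 `Nc1scc(CN2CCN(c3ccc(C(F)(F)F)cc3)CC2)c1C(=O)c1cccc(C(F)(F)F)c1` gives 0% in this assay, and compound 3 `Nc1scc(CN2CCN(c3cccc(F)c3)CC2)c1C(=O)c1ccc(Cl)cc1` gives 4%; compound 2 thus stands second highest of the three numbers, all of which lie within the scatter of one another. Compound 4 `Nc1scc(CN2CCN(c3cc(Cl)ccc3Cl)CC2)c1C(=O)c1ccc(Cl)cc1` is not yet measured; it differs from compound 2 by 2,5-dichlorophenyl in place of cyclopentyl on an amine nitrogen in a ring. Among the measured compounds shown here, the one measured step that bears on this is a number 1 percentage points higher from compound 2 to compound 3 (within the scatter), likewise a substituent in place of cyclopentyl on an amine nitrogen in a ring. No change beyond the scatter is therefore expected in this assay. The estimated step is no change at the digits printed from compound 2 to compound 4 (within the scatter). For compound 4 the expected value is 3%, with a range from -5% to 15%.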

Compound 4, a percentage reported as inhibition, at one concentration (the size of the read-out at that concentration, not a potency): 1%
Compound 4: the middle estimate sits 2 percentage points above what was measured; measured number inside the range.
By their numbers in this assay, from the lowest: compounds 1, 4, 2 and 3 (each within the scatter of the next).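

On the amine nitrogen in the ring, 2,5-dichlorophenyl in place of cyclopentyl leaves this assay reading a number 2 percentage points lower from compound 2 to compound 4 (within the scatter), and in place of 3-fluorophenyl it reads a number 3 percentage points lower from compound 3 to compound 4 (within the scatter). Cyclopentyl, 3-fluorophenyl and now a phenyl carrying two chlorines therefore cannot be told apart at this position, with all three numbers close to zero. No measurement on hand offers an explanation for this flat result. On these data alone, whether any group at this nitrogen can raise the inhibition remains open, for instance a benzyl group, a longer alkyl chain or a carboxylic acid. With numbers this low, the compounds shown give no ranking of these groups.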